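Thiophene sulfonamides and ureas on RS4-11 cells

The compounds below may be only part of what the source reports. "The series", "measured", "known", "first", "only" and "open" are said of these compounds alone.

Measured so far:
compound 1, `COc1ccc(Oc2ccccc2-c2ccsc2S(=O)(=O)N2CCN(C(=O)Nc3ccc([N+](=O)[O-])cc3)CC2)cc1OC` — > 50000 nM
compound 2, `O=C(Nc1cccc([N+](=O)[O-])c1)N1CCN(S(=O)(=O)c2sccc2-c2ccccc2Oc2ccc(O)c(O)c2)CC1` — 9800 nM
compound 3, `O=S(=O)(NCCNC(=S)Nc1cccc(Cl)c1)c1ccc(-c2ccccc2OCc2ccccc2)s1` — > 50000 nM

Within the data shown here, in a functional assay on RS4-11 cells (Homo sapiens) for inhibition, read by CCK-8 assay, with a stated time of 48 h (on this read-out higher numbers stand for weaker inhibition and lower numbers for stronger inhibition), compound 2 gives 9800 nM and is the only one with a number. Compound 1 sits at a limit of this assay, > 50000 nM. Compound 3 likewise sits at a limit of this assay, > 50000 nM, so no inhibition is resolved for it. Compound 4, `O=[N+]([O-])c1cccc(NC(=S)NCCNS(=O)(=O)c2ccc(-c3ccccc3OCc3ccccc3)s2)c1`, differs from compound 3 by nitro in place of chloro on an aromatic carbon. Among the measured compounds shown here, no measured pair that shares this change exists here, so nothing sets its size or direction. Since compound 3 shows only a limit, a step of a number no higher from compound 3 to compound 4 (the limit leaves the size open) of none beyond the scatter is expected. Compound 4 is estimated at 50000 nM, within 15000 nM to 150000 nM.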

Compound 4, half-maximal inhibitory concentration: 11600 nM
Estimate against measurement, compound 4: 4.3-fold (0.63 log units) above; the measured number lies below the stated range.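

In this assay, among these compounds, 3-chlorophenyl to 3-nitrophenyl gives an at least 4.3-fold lower number from compound 3 to compound 4 (0.63 log units; beyond the scatter), the first readable step, so this position, meta to a large group, does respond to substitution. On these data alone, compound 3 gives only a limit, > 50000 nM, so the full size of the step stays open: the limit of > 50000 nM in this assay, at which 2 of the 4 values shown sit.

As far as these compounds go, whether an amine or a carboxylic acid at this position would match nitro remains open. Also open, from the compounds shown here alone, is whether the same change from chloro to nitro would shift the number on the core of compound 2.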